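The source may hold more compounds than are shown below. What is called first, only, known or untested is meant among the compounds shown, and "the series" means these compounds.

Three compounds have been measured in a functional assay on the whole organism (strain Icem-CET (SPF Caw)) for inhibition, with Mus musculus as the target, with a stated time of 30 min; a higher number here means that more compound is needed for the effect, a lower number that less compound is needed:
compound 1, `C#CCNC(=O)/C(C)=C(\C)c1ccc(Cl)cc1`, 10.6 mg/kg
compound 2, `C#CCNC(=O)/C(C)=C(\C)c1ccccc1`, 45.3 mg/kg
compound 3, `C=CCNC(=O)/C(C)=C(\C)c1ccc(Cl)cc1`, 18.6 mg/kg

Compound 4, `C=CCNC(=O)/C(C)=C(\C)c1ccccc1`, has not yet been measured. It shares the core of compound 3, and that core differs from the core of compound 1 by vinyl in place of ethynyl on a saturated chain carbon bound to an amide-type nitrogen, a change that produced a 1.8-fold higher number from compound 1 to compound 3 (0.24 log units; within the scatter). The change from compound 3 to compound 4 is hydrogen in place of chloro on an aromatic carbon. The same change has been made once before among these compounds, as hydrogen in place of chloro on an aromatic carbon, where it gave a 4.3-fold higher number from compound 1 to compound 2 (0.63 log units; beyond the scatter). The place of the change is the same in both cases, so it counts as the same change. Compound 4 is therefore expected to move by about a 4.0-fold higher number from compound 3 to compound 4 (0.61 log units; beyond the scatter) in this assay, because the same change gave a 4.3-fold higher number from compound 1 to compound 2 (0.63 log units; beyond the scatter) on the core of compound 1. The estimate rests on a single earlier step, so the range is kept wide. For compound 4 a value of 75 mg/kg is expected, between 35 mg/kg and 160 mg/kg.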

Compound 4, dose for half-maximal effect: 67 mg/kg
Compound 4: the middle estimate sits 1.1-fold (0.05 log units) above what was measured; the measured number falls inside the stated range.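

In this assay, hydrogen in place of chloro on an aromatic carbon gave a 3.6-fold higher number from compound 3 to compound 4 (0.56 log units; beyond the scatter), so the loss of the chloro carried over from the ethynyl compounds to the vinyl compounds at much the same size: the same change on two cores in this assay, a 4.3-fold higher number (0.63 log units; beyond the scatter) from compound 1 to compound 2 and a 3.6-fold higher number (0.56 log units; beyond the scatter) from compound 3 to compound 4, 1.2-fold (0.07 log units) apart, within the scatter of two such steps. Vinyl in place of ethynyl gave a 1.5-fold higher number from compound 2 to compound 4 (0.17 log units; within the scatter), and this step also agrees across the two cores, although on neither core can it be told apart from the scatter: the same change on two cores in this assay, a 1.8-fold higher number (0.24 log units; within the scatter) from compound 1 to compound 3 and a 1.5-fold higher number (0.17 log units; within the scatter) from compound 2 to compound 4, 1.2-fold (0.07 log units) apart, within the scatter of two such steps. The two changes therefore behave as independent of each other in these four compounds, but that rests on a single square of compounds and says nothing about why either change acts as it does, or whether it would hold on any other core.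

The compounds shown leave open whether fluoro, methoxy or a nitrile on the aromatic ring would follow the chloro. They also leave open how a propyl group or a longer chain on the amide nitrogen would compare with the ethynyl and vinyl chains.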